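Swapping Nitro for Fluoro on a Shared Core

A few compounds are considered here, and "the series" means these few. Any claim that something is new, unique, unknown or untested is made for them only; others in the source may bear on it.

Three close relatives of one core have been examined for harm to cells. Compound 1 `COc1ccc(CNc2cc(-c3ccco3)nc(Cl)n2)cc1` carries in an ADME assay on Vero cells (Chlorocebus sabaeus) for cytotoxicity, read by MTT assay, with a stated time of 72 h (on this read-out higher numbers stand for weaker inhibition and lower numbers for stronger inhibition), no result, "not determined" (no result reported). Compound 2 `COc1ccc(CNc2ncnc(-c3ccco3)c2NC=O)cc1` reaches in this assay only a limit, > 40 ug/mL. Compound 3 `COc1ccc(CNc2nc([N+](=O)[O-])nc(-c3ccco3)c2NC=O)cc1` also reaches in this assay only a limit, > 40 ug/mL. Among the measured compounds shown here, the single measured step, a step that the two limits leave unreadable from compound 2 to compound 3, cannot be read because both ends sit at the limit of > 40 ug/mL in this assay, at which 2 of the 3 values shown sit. Compound 3 thus stands at the assay's upper boundary, with compound 2 at the same boundary and compound 1 without a number.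

Compound 4 `COc1ccc(CNc2nc(F)nc(-c3ccco3)c2NC=O)cc1` differs from compound 3 in one place: fluoro in place of nitro on an aromatic carbon. For the measured compounds named here, no measured step speaks to this exchange beyond the unreadable a step that the two limits leave unreadable from compound 2 to compound 3, so there is no evidence that the swap moves cytotoxicity at all. The expectation for compound 4 is therefore a step that the limit leaves unreadable from compound 3 to compound 4 of no size beyond the scatter. Compound 4 is estimated to give 50 ug/mL, within a range from 25 ug/mL to 120 ug/mL.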

Compound 4, half-maximal inhibitory concentration: > 40 ug/mL
Compound 4: only a limit was reported; the forecaster's own chance of this, stated with the estimate: 70%; the middle value does not contradict the limit.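

In this assay compound 4 gives only a limit, > 40 ug/mL. The steps among compound 2, compound 3 and compound 4 therefore cannot be read, because all three share one boundary: the limit of > 40 ug/mL in this assay, at which 3 of the 4 values shown sit. On these data alone, whether hydrogen, nitro or fluoro at this place changes harm to cells at all remains open.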